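The source may report more compounds than this note shows. Statements on the series, on what has been measured and on what is new or still open speak of the compounds shown alone.

Compound 3 `COC(=O)[C@H](CCSC)NC(=O)c1ccc(NCc2cncn2Cc2cccc(C)c2)cc1-c1ccccc1` is one of three compounds that share a core and were tested in a functional assay on NIH3T3 cells (Mus musculus); a higher number here means that more compound is needed for the effect, a lower number that less compound is needed. In this assay compound 3 reaches only the limit > 10 uM. Compound 1 `COC(=O)[C@H](CCSC)NC(=O)c1ccc(NCc2cncn2Cc2cccc(C#N)c2)cc1-c1ccccc1` likewise gives only the limit > 10 uM in this assay. Compound 2 `COC(=O)[C@H](CCSC)NC(=O)c1ccc(NCc2cncn2Cc2ccccc2C#N)cc1-c1ccccc1` also returns only the limit > 10 uM in this assay. Compound 3 thus stands at a limit, and the two further values shown are limits as well, (the limit of > 10 uM in this assay, at which 3 of the 3 values shown sit). The steps among these three, a step that the two limits leave unreadable from compound 1 to compound 2, a step that the two limits leave unreadable from compound 1 to compound 3 and a step that the two limits leave unreadable from compound 2 to compound 3, are all of unreadable size, so none of them tells how a change on that aromatic ring moves the read-out. Compound 4 `COC(=O)[C@H](CCSC)NC(=O)c1ccc(NCc2cncn2Cc2cccc(Cl)c2)cc1-c1ccccc1` differs from compound 3 by chloro in place of methyl on an aromatic carbon. With every step bearing on this position unreadable, no direction beyond the scatter can be expected in this assay, and the most likely outcome is once more a limit. Compound 4 is therefore estimated at 20 uM, within 5 uM to 80 uM. The step this estimate means is expected to read a step that the limit leaves unreadable from compound 3 to compound 4.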

Compound 4, concentration for half-maximal effect: > 10 uM
Compound 4 was reported as a limit; the forecaster's own chance of this, stated with the estimate: 80%; the middle value lies beyond the limit too.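

Compound 4 sits at a limit in this assay, as do compound 1, compound 2 and compound 3, so no step among these four can be read: the limit of > 10 uM in this assay, at which 4 of the 4 values shown sit.

The compounds shown leave open how chloro, methyl and cyano on this aromatic ring compare, and what change to the shared core would give a readable value.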